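Swapping a Sulfanyl Linker for a Benzylamine

This account rests on a few compounds, and the source may have more. Where it says the series, first, only, none or still open, it means among the compounds named here.

For the measured compounds named here, compound 1 `Nc1cc(N)c2nc(-c3ccccc3)c(Sc3ccc(F)cc3)nc2c1` gives 31600 nM in a functional assay on SK-OV-3 cells (Homo sapiens) for inhibition, read by sulforhodamine B assay, with a stated time of 48 h (a higher number here means a weaker inhibitor of growth, a lower number a stronger inhibitor of growth), the lower of the two numbers known so far. Compound 2 `CCOC(=O)[C@H](CCC(=O)O)NC(=O)c1ccc(Oc2nc3cc(N)cc(N)c3nc2-c2ccccc2)cc1` gives 97700 nM in this assay, and the gap between compound 1 and compound 2 lies beyond the usual scatter. Compound 3 `Nc1cc(N)c2nc(-c3ccccc3)c(NCc3ccc(F)cc3)nc2c1` has not been measured; it differs from compound 1 by (4-fluorobenzyl)amino in place of (4-fluorophenyl)sulfanyl on an aromatic carbon. Going by the values given here, no measured pair shows this kind of change, so the step of a 1.3-fold lower number from compound 1 to compound 3 (0.10 log units; within the scatter) is expected to be small, possibly none beyond the scatter, in either direction. Compound 3 is estimated at 25000 nM, within a range of 8000 nM to 80000 nM.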

Compound 3, concentration for total growth inhibition: 26300 nM
Estimate against measurement, compound 3: 1.1-fold (0.02 log units) below, and the stated range covers the measured number.
By their numbers in this assay, from the lowest: compounds 3 and 1 (each within the scatter of the next); then compound 2.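

In this assay, placing (4-fluorobenzyl)amino on the aromatic carbon next to the ring nitrogen, where (4-fluorophenyl)sulfanyl stood, gives a 1.2-fold lower number from compound 1 to compound 3 (0.08 log units; within the scatter), the first step read at this position. This position therefore tolerates the exchange of the sulfanyl link for a benzylamine, even though the entering group carries a hydrogen-bond donor that the leaving group lacks. No evidence bears on why the number holds. Going by these compounds, whether a simple amine, a longer chain or a carboxylic acid at this position would shift the number remains open.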